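A Single Methyl Added on the Amide-Bearing Phenyl

The source may hold more compounds than are shown below. What is called first, only, known or untested is meant among the compounds shown, and "the series" means these compounds.

Compound 1 `COc1ccc2c(=O)c(/C=C/C(=O)Nc3ccccc3)coc2c1` is the starting point. In a functional assay on Huh-7 cells (Homo sapiens) for inhibition, read by MTT assay, with a stated time of 48 h (on this read-out higher numbers stand for weaker inhibition and lower numbers for stronger inhibition), compound 1 gives 9050 nM. Two other compounds share its core and differ only in the group on the amide-type nitrogen. Compound 2 `COc1ccc2c(=O)c(/C=C/C(=O)Nc3cc(C)ccc3C)coc2c1` gives 11100 nM in this assay, and compound 3 `COc1ccc2c(=O)c(/C=C/C(=O)NCc3ccccc3F)coc2c1` gives 8450 nM. The number for compound 1 is the second highest of the three, with compound 3 nearest and compound 2 furthest, yet all three lie within the scatter of one another, so none can be called stronger or weaker.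

Compound 4 `COc1ccc2c(=O)c(/C=C/C(=O)Nc3ccccc3C)coc2c1` differs from compound 1 by methyl in place of hydrogen on an aromatic carbon. The closest measured step is a 1.2-fold higher number from compound 1 to compound 2 (0.09 log units; within the scatter), where 2,5-dimethylphenyl replaces phenyl on the amide-type nitrogen and the number stays within the scatter. The step of a 1.1-fold lower number from compound 1 to compound 3 (0.03 log units; within the scatter) also changes that group without an effect beyond the scatter. A single methyl is therefore expected to bring no step beyond the scatter, a 1.0-fold lower number from compound 1 to compound 4 (0.00 log units; within the scatter). Compound 4 is estimated at 9000 nM, within a range from 5000 nM to 16000 nM.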

Compound 4, half-maximal inhibitory concentration: 26900 nM
Compound 4: middle estimate off by 3.0-fold (0.48 log units), on the low side; measured number above the stated range.
By their numbers in this assay, from the lowest: compounds 3, 1 and 2 (each within the scatter of the next); then compound 4.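

Within the data shown here, the methyl on this aromatic carbon, ortho to a large group, is not a silent change: with a 3.0-fold higher number from compound 1 to compound 4 (0.47 log units; beyond the scatter), it gives the first step beyond the scatter, in the direction of weaker inhibition. The 2-methylphenyl group also stands apart from 2-fluorobenzyl on the amide-type nitrogen, with a 3.2-fold higher number from compound 3 to compound 4 (0.50 log units; beyond the scatter). The methyl's step also depends on the rest of the ring, since removing the second methyl of 2,5-dimethylphenyl gives a 2.4-fold higher number from compound 2 to compound 4 (0.38 log units; beyond the scatter), although compound 2 itself lies within the scatter of compound 1.

As far as these compounds go, whether chlorine, methoxy or a longer chain such as ethyl at this place would give a similar step remains open. Nothing available here explains why one methyl weakens inhibition while two on the 2,5-dimethylphenyl ring do not.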